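Hydroxymethyl in Place of Sec-Butyl on the Shared Core

The source may report more compounds than this note shows. Statements on the series, on what has been measured and on what is new or still open speak of the compounds shown alone.

Compound 1 `CC[C@H](C)[C@H](NC(=O)CN(c1nc(Cl)nc2[nH]cnc12)C1CC1)C(=O)OCc1ccccc1`: 22%
Compound 2 `NC(=O)CC[C@H](NC(=O)CN(c1ncnc2c1ncn2C1CCCCO1)C1CC1)C(=O)OCc1ccccc1`: 22.3%
Compound 3 `CC[C@H](C)[C@H](NC(=O)CN(c1nc(Cl)nc2[nH]cnc12)C1CC1)C(=O)O`: 21.4%

In a functional assay on the whole organism (Tail, strain ICR) with Mus musculus as the target, in the tail flick test, with a stated time of 120 min, at a dose of 25 umol/kg by the oral route (on this read-out lower numbers stand for a weaker effect and higher numbers for a stronger effect at the one dose given), compound 1 gives 22%, and the values of compound 2 and compound 3 lie within the scatter of that number, so no order among the three can be read. Compound 4 `O=C(CN(c1nc(Cl)nc2[nH]cnc12)C1CC1)N[C@@H](CO)C(=O)OCc1ccccc1` differs from compound 1 by hydroxymethyl in place of sec-butyl on a saturated chain carbon bound to an amide-type nitrogen and a carbonyl carbon. For the measured compounds named here, only one measured step exists, a number 0.6 percentage points lower from compound 1 to compound 3 (within the scatter), and it concerns the oxygen bound to the carbonyl, not the chain carbon changed here, so it bears on compound 4 only loosely. Nothing measured shows a change at this position moving the number. Compound 4 is therefore expected to give about 22%, between 10% and 34%, an expected step of no change at the digits printed from compound 1 to compound 4 (within the scatter).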

Compound 4, a percentage reported as activity, at one dose (the size of the read-out at that dose, not a potency): 34.5%
Estimate against measurement, compound 4: 12.5 percentage points below; the measured number lies above the stated range.
By their numbers in this assay, from the lowest: compounds 3, 1 and 2 (each within the scatter of the next); then compound 4.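

In this assay, the step of a number 12.5 percentage points higher from compound 1 to compound 4 (beyond the scatter) comes with hydroxymethyl in place of sec-butyl on a saturated chain carbon bound to an amide-type nitrogen and a carbonyl carbon, so this carbon is a place where a change can move the number beyond the scatter. The earlier step, at the oxygen bound to the carbonyl, had stayed within it. No measurement at hand accounts for this rise. As far as these compounds go, whether a methyl, an aminomethyl or a hydroxyethyl group on this carbon would give a similar number stays open. So does whether hydroxymethyl would do the same with the carboxylic acid of compound 3.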